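A few compounds are considered here, and "the series" means these few. Any claim that something is new, unique, unknown or untested is made for them only; others in the source may bear on it.

Values so far from an ADME assay on microsomes from liver (Mus musculus) for metabolic stability, read by LC-MS, with a stated time of 30 min, tested at 1 uM; on this read-out higher numbers stand for a more stable compound and lower numbers for a less stable compound
Compound 1 `CC[C@@H]1CC[C@@H](C(=O)N2CCOCC2)N1C(=O)C1=C(C(C)C)N2C(=N[C@@](C)(c3ccc(Cl)cc3)[C@H]2c2ccc(Cl)cc2)S1` with 6% remaining
Compound 2 `CC(C)C1=C(C(=O)N2[C@H](C)CC[C@H]2C(=O)N2CCN(C)C(C)(C)C2)SC2=N[C@@](C)(c3ccc(Cl)cc3)[C@@H](c3ccc(Cl)cc3)N21` with 84% remaining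

Compound 1 is the lower of the two, and the gap up to compound 2 lies beyond the scatter. Compound 3 `CC[C@@H]1CC[C@@H](C(=O)N2CCN(C(C)=O)[C@@H](C)C2)N1C(=O)C1=C(C(C)C)N2C(=N[C@@](C)(c3ccc(Cl)cc3)[C@H]2c2ccc(Cl)cc2)S1` keeps the core of compound 1 and changes one group on a carbonyl carbon: a group of 10 heavy atoms (7 carbon, 2 nitrogen, 1 oxygen; one six-membered non-aromatic ring with 2 hetero atoms) in place of a group of 6 heavy atoms (4 carbon, 1 nitrogen, 1 oxygen; one six-membered non-aromatic ring with 2 hetero atoms), on a carbonyl carbon describes the swap. Going by the values given here, no measured pair isolates a change like this. Compound 2 stands at 84% but differs from compound 1 in more than one place, so it is only a loose guide. A rise beyond the scatter is expected, with a number 22 percentage points higher from compound 1 to compound 3 (beyond the scatter) as the estimated step. For compound 3 the estimated value is 28% with a range from 8% to 60% expected.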

Compound 3, percent of the compound remaining: 54%
The estimate for compound 3 lay 26 percentage points below the measured number; the measured number falls inside the stated range.
By their numbers in this assay, from the lowest: compound 1; then compound 3; then compound 2.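

In this assay, putting the group of 10 heavy atoms in place of morpholin-4-yl on this carbonyl carbon gives a number 48 percentage points higher from compound 1 to compound 3 (beyond the scatter). With the rest of the molecule unchanged, this single position can therefore shift the read-out by a large amount, something the earlier pair, which differs in more than one place, could not show. No separate evidence bears on why the number rises. Which part of the larger group carries the step stays open, as does the outcome with an open-chain amine such as dimethylamine on this carbonyl carbon.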